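A methyl added to the phenylsulfonyl of compound 3

The compounds below may be only part of what the source reports. "The series", "measured", "known", "first", "only" and "open" are said of these compounds alone.

Measured so far in a functional assay on NB1 cells (Homo sapiens) for cytotoxicity, read by MTT assay, with a stated time of 3 days (on this read-out higher numbers stand for weaker inhibition and lower numbers for stronger inhibition), are three compounds:
- compound 1 `N#Cc1c(-c2ccccc2)nc(SCc2nc3ccccc3[nH]2)nc1N1CCNCC1` gives 6.75 nM
- compound 2 `CN1CCN(c2nc(SCc3nc4ccccc4[nH]3)nc(-c3ccccc3)c2C#N)CC1` gives 2.4 nM
- compound 3 `N#Cc1c(-c2ccccc2)nc(SCc2nc3ccccc3[nH]2)nc1N1CCN(S(=O)(=O)c2ccccc2)CC1` gives 3.28 nM

Compound 3 cannot be separated from compound 2, with a 1.4-fold higher number from compound 2 to compound 3 (0.14 log units; within the scatter). Compound 1 stands apart from it, with a 2.1-fold lower number from compound 1 to compound 3 (0.31 log units; beyond the scatter).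

Compound 4 `Cc1ccc(S(=O)(=O)N2CCN(c3nc(SCc4nc5ccccc5[nH]4)nc(-c4ccccc4)c3C#N)CC2)cc1` has not yet been measured. It turns the phenylsulfonyl of compound 3 into (4-methylphenyl)sulfonyl, with methyl in place of hydrogen on an aromatic carbon. For the measured compounds named here, no measured step tests this aromatic carbon directly. The nearest evidence comes from changes on the ring amine nitrogen, and those are small. They are a 2.8-fold lower number from compound 1 to compound 2 (0.45 log units; beyond the scatter) and a 2.1-fold lower number from compound 1 to compound 3 (0.31 log units; beyond the scatter), both modest, and a 1.4-fold higher number from compound 2 to compound 3 (0.14 log units; within the scatter). Even replacing methyl with the whole phenylsulfonyl group therefore left the number in this assay within the scatter, so no step beyond the scatter is expected here. The estimated change is a 1.0-fold lower number from compound 3 to compound 4 (0.01 log units; within the scatter). Compound 4 is expected at an estimated 3.2 nM, with 1.4 nM to 7.5 nM as its likely range.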

Compound 4, half-maximal inhibitory concentration: 6.75 nM
Estimate against measurement, compound 4: 2.1-fold (0.32 log units) below; the range from low to high includes it.
By their numbers in this assay, from the lowest: compounds 2 and 3 (each within the scatter of the next); then compounds 1 and 4 (each within the scatter of the next).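

In this assay, the aromatic carbon of the phenylsulfonyl group proves responsive to substitution, since a single added methyl gives a 2.1-fold higher number from compound 3 to compound 4 (0.31 log units; beyond the scatter) and this step lies beyond the scatter, whereas every earlier step changed the ring amine nitrogen. The advantage of the sulfonyl series over compound 1 does not survive this methyl: there is a 2.8-fold higher number from compound 2 to compound 4 (0.45 log units; beyond the scatter) and no change at the digits printed from compound 1 to compound 4 (within the scatter) here, so the hydrogen on the nitrogen of compound 1 and the (4-methylphenyl)sulfonyl group cannot be told apart in this assay. Nothing available explains the effect of the methyl.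

The compounds shown leave open whether this step belongs to methyl alone or would also follow from a chlorine, a methoxy group or an amine on this aromatic carbon. They also leave open whether a longer chain there would move the number further.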